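A Fluoro Step Repeated on a Second Core

The source may report more compounds than this note shows. Statements on the series, on what has been measured and on what is new or still open speak of the compounds shown alone.

Three compounds have been measured in a functional assay on MCF7 cells (Homo sapiens) for cytotoxicity, read by MTT assay, with a stated time of 72 h; a lower number here means a stronger inhibitor, a higher number a weaker inhibitor:
Compound 1, `O=C(Nc1ccc(Oc2ccnc3[nH]ccc23)c(F)c1)c1nn(-c2ccc(Br)cc2)ccc1=O`, gives 11600 nM.
Compound 2, `O=C(Nc1ccc(Oc2ccnc3[nH]ccc23)c(F)c1)c1nn(-c2ccc(Br)cc2F)ccc1=O`, gives 23500 nM.
Compound 3, `Cn1ccc2c(Oc3ccc(NC(=O)c4nn(-c5ccc(Cl)cc5)ccc4=O)cc3)ccnc21`, gives only a limit of the assay, > 60000 nM.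

Compound 1 and compound 2 differ by fluoro in place of hydrogen on an aromatic carbon, and in this assay the step is a 2.0-fold higher number from compound 1 to compound 2 (0.31 log units; beyond the scatter). The difference between the core of compound 1 and the core of compound 3 is not broken down here. For the measured compounds named here, compound 3 sits at the limit, and the limit of > 60000 nM in this assay, at which 1 of the 3 values shown sits, is the only evidence on where it stands.

Compound 4, `Cn1ccc2c(Oc3ccc(NC(=O)c4nn(-c5ccc(Cl)cc5)ccc4=O)cc3F)ccnc21`, has not been measured. It differs from compound 3 by fluoro in place of hydrogen on an aromatic carbon. Going by the values given here, this is the same kind of change as the one from compound 1 to compound 2, though not the same: in the measured pair the new fluoro sits meta to a bromo group, whereas in compound 4 it sits meta to a large group. On the first core the change gave a modestly higher number, and compound 3 already shows only a limit, so compound 4 is expected to give a number no lower than that limit, an expected step that the limit leaves unreadable from compound 3 to compound 4. Because compound 3 gives > 60000 nM, the estimate for compound 4 in this assay is 100000 nM, with a range from 40000 nM to 250000 nM, and most likely only a limit will again be reported.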

Compound 4, half-maximal inhibitory concentration: > 60000 nM
Compound 4: a limit, no number; the forecaster's own chance of this, stated with the estimate: 85%; the middle value lies beyond the limit too.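

Compound 3 and compound 4 both stand at a limit in this assay rather than at a number, so no step can be read between them: the limit of > 60000 nM in this assay, at which 2 of the 4 values shown sit. The compounds shown leave open whether fluoro in place of hydrogen on an aromatic carbon changes the result at all on the core of compound 3, and how far past the limit either compound lies.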